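Moving the bromine on the sulfur-linked phenyl in a weakly active series

A few compounds are considered here, and "the series" means these few. Any claim that something is new, unique, unknown or untested is made for them only; others in the source may bear on it.

The compounds share a core in which an enone carbon bears a sulfur-linked bromophenyl and a chlorophenyl ketone. In a functional assay on DU-145 cells (Homo sapiens) for inhibition, read by trypan blue exclusion, with a stated time of 96 h (on this read-out lower numbers stand for stronger inhibition of growth and higher numbers for weaker inhibition of growth), compound 1 `O=C(/C(=C\c1ccc(O)cc1O)Sc1ccc(Br)cc1)c1ccc(Cl)cc1` gives 50000 nM, compound 2 `O=C(/C(=C\c1cc(Cl)cc(Cl)c1Cl)Sc1ccccc1Br)c1ccc(Cl)cc1` gives 25000 nM, and compound 3 `O=C(/C(=C\c1c(O)cc(O)cc1O)Sc1ccc(Br)cc1)c1ccc(Cl)cc1` gives 50000 nM. Compound 3 is level with compound 1 and the two stand together at the top of the three numbers; compound 2 lies a little lower, but that gap is within the scatter, so no order can be read among the three. Among the compounds with values here, the only single-point step in the set, no change at the digits printed from compound 1 to compound 3 (within the scatter), shows that adding a hydroxy leaves this assay unmoved.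

Compound 4 `O=C(/C(=C\c1c(O)cc(O)cc1O)Sc1ccccc1Br)c1ccc(Cl)cc1` differs from compound 3 by 2-bromophenyl in place of 4-bromophenyl on a sulfur. Within the data shown here, no measured pair isolates this change: compound 2 does carry a 2-bromophenyl on its sulfur, yet it also differs in the other aryl, so its value shows only that a 2-bromophenyl compound sits within the scatter of the 4-bromophenyl compounds. Among the measured compounds shown here, with no step bearing on the change, the expectation for compound 4 is no movement beyond the scatter, a 1.3-fold lower number from compound 3 to compound 4 (0.10 log units; within the scatter). Compound 4 is therefore estimated at 40000 nM, within 15000 nM to 100000 nM.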

Compound 4, concentration for 50% growth inhibition: > 100000 nM
Compound 4 gave a limit, no number; the forecaster's own chance of this, stated with the estimate: 20%; middle value at least 2.5-fold (0.39 log units) away from the limit.
By their numbers in this assay, from the lowest: compounds 2, 1 and 3 (each within the scatter of the next). At a limit, above all of these: compound 4.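

In this assay, within the data shown here, compound 4 stands at a limit and not at a number, the only such value in the set: the limit of > 100000 nM in this assay, at which 1 of the 4 values shown sits. Putting 2-bromophenyl in place of 4-bromophenyl on a sulfur gives an at least 2.0-fold higher number from compound 3 to compound 4 (0.30 log units; that floor lies within the scatter), so this step's floor does not clear the scatter and the limit leaves its true size unknown, but unlike the earlier hydroxy step it no longer reads as no change at the digits printed. With the 2-bromophenyl held fixed, 2,4,6-trihydroxyphenyl in place of 2,3,5-trichlorophenyl on a double-bonded chain carbon gives an at least 4.0-fold higher number from compound 2 to compound 4 (0.60 log units; beyond the scatter), the only step shown that lies beyond the scatter, so between these two compounds the read-out does respond to the other aryl group.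

From the compounds shown here alone, how far the bromine move reaches remains open, as does whether it would register in the same way with 2,3,5-trichlorophenyl on the double-bonded chain carbon. Also open, going by these compounds, is what an unsubstituted phenyl or an aminophenyl on the sulfur would give in this assay.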